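Pyridin-4-yl in Place of Phenyl on the Shared Core

The source may report more compounds than this note shows. Statements on the series, on what has been measured and on what is new or still open speak of the compounds shown alone.

Compound 1 `COc1cc(C(F)(F)F)cc(SC)c1C(=O)NC1(c2ccccc2)CCCN(C)C1` is the starting point of this account. In an assay on cells for inhibition of sodium- and chloride-dependent glycine transporter 1 (Homo sapiens) (on this read-out lower numbers stand for an effect already at smaller amounts and higher numbers for an effect only at larger amounts of compound), compound 1 gives 24 nM, the lowest of the two numbers recorded so far. Its closest neighbour is compound 2 `COc1cc(C(F)(F)F)cc(SC)c1C(=O)N[C@]1(c2ccccc2)CCCN(C)C1`, which in this assay gives 180 nM. Among the measured compounds shown here, the step of a 7.5-fold higher number from compound 1 to compound 2 (0.88 log units; beyond the scatter) is the only measured step in this set, and it concerns a stereocentre at a saturated ring carbon, a difference that rests on the fact that one of compounds 1 and 2 is drawn with a defined configuration and the other without, at the place where they differ alone.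

Compound 3 `COc1cc(C(F)(F)F)cc(SC)c1C(=O)NC1(c2ccncc2)CCCN(C)C1` differs from compound 1 in another way: pyridin-4-yl in place of phenyl on a saturated ring carbon. For the measured compounds named here, no measured step in this set touches an exchange of an aromatic ring on that carbon, so the step from compound 1 to compound 2 offers no direct guide to the size or direction of the change to compound 3. Without such a guide, only a modest shift is expected, somewhat toward higher numbers, as a 2.5-fold higher number from compound 1 to compound 3 (0.40 log units; beyond the scatter) expresses. Compound 3 is therefore estimated at 60 nM in this assay, within a range from 15 nM to 250 nM.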

Compound 3, half-maximal effective concentration: 60 nM
Beside the measured number, compound 3's estimate shows no gap at the digits printed, within the range that was stated.
By their numbers in this assay, from the lowest: compound 1; then compound 3; then compound 2.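

In this assay, among the compounds shown here, the exchange of phenyl for pyridin-4-yl on the saturated ring carbon gives a 2.5-fold higher number from compound 1 to compound 3 (0.40 log units; beyond the scatter), which makes this the first reading of a change to the aromatic ring at this position, and it shows that the ring is not a silent part of the shared core. The step is modest, so on this core the position still accepts a six-membered aromatic ring with a hetero atom, at the same count of heavy atoms as phenyl and with one hydrogen-bond acceptor more. Nothing in the material given accounts for the direction or the size of this step.

The compounds shown leave open whether the step belongs to pyridin-4-yl specifically or would recur with pyridin-3-yl, pyridin-2-yl or a fluorophenyl ring on the same carbon. For the compounds shown here, they also leave open how a defined configuration at that carbon would act with pyridin-4-yl in place, since the only such reading, a 7.5-fold higher number from compound 1 to compound 2 (0.88 log units; beyond the scatter), carries phenyl.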